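Shifting one methyl on the dimethylphenyl group

The source may hold more compounds than are shown below. What is called first, only, known or untested is meant among the compounds shown, and "the series" means these compounds.

In a functional assay on KB cells (Homo sapiens) for antiproliferative activity, read by sulforhodamine B assay, with a stated time of 3 days (on this read-out higher numbers stand for an effect only at larger amounts of compound and lower numbers for an effect already at smaller amounts), compound 1 `CCC1=C(O)c2c(oc(-c3ccc(C)cc3)cc2=O)C(CC)(CC)C1=O` gives 39.2 uM, compound 2 `CCC1=C(O)c2c(oc(-c3ccc(O)cc3)cc2=O)C(CC)(CC)C1=O` gives 20.6 uM and compound 3 `CCC1=C(O)c2c(oc(-c3cc(C)ccc3C)cc2=O)C(CC)(CC)C1=O` gives 14.5 uM. Compound 3 therefore stands with two comparisons: a 1.4-fold lower number from compound 2 to compound 3 (0.15 log units; within the scatter), and a 2.7-fold lower number from compound 1 to compound 3 (0.43 log units; beyond the scatter). Compound 4 `CCC1=C(O)c2c(oc(-c3cc(C)cc(C)c3)cc2=O)C(CC)(CC)C1=O` has 3,5-dimethylphenyl in place of 2,5-dimethylphenyl on an aromatic carbon. Within the data shown here, no measured step isolates such a shift. The closest one, a 2.7-fold lower number from compound 1 to compound 3 (0.43 log units; beyond the scatter), also changes the aryl methyl pattern and is only modest, while a 1.9-fold lower number from compound 1 to compound 2 (0.28 log units; within the scatter) stays small. A small rise is expected, with a 1.4-fold higher number from compound 3 to compound 4 (0.14 log units; within the scatter) estimated to stay within the scatter. Compound 4 is expected at about 20 uM, with an estimated range of 9 uM to 42 uM.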

Compound 4, concentration for half-maximal effect: 45.5 uM
The estimate for compound 4 lay 2.3-fold (0.36 log units) below the measured number, and the stated range ends below it.
By their numbers in this assay, from the lowest: compounds 3, 2, 1 and 4 (each within the scatter of the next, the first and the last beyond it).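

Shifting one methyl, with the atoms unchanged, gives a 3.1-fold higher number from compound 3 to compound 4 (0.50 log units; beyond the scatter) in this assay and so shows that the arrangement of the methyls alone can change the number at this aromatic carbon. Compared with the hydroxylated compound, the same group gives a 2.2-fold higher number from compound 2 to compound 4 (0.34 log units; beyond the scatter) and thus stays beyond the scatter. Against the single-methyl compound, it gives a 1.2-fold higher number from compound 1 to compound 4 (0.06 log units; within the scatter) and remains within the scatter, so a second methyl does not by itself lower the number. From the compounds shown here alone, whether an amine or a carboxylic acid on this aryl ring would lower it further remains open. The data offer no explanation of why the 2,5-dimethylphenyl and 3,5-dimethylphenyl groups differ.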